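This account rests on a few compounds, and the source may have more. Where it says the series, first, only, none or still open, it means among the compounds named here.

For the measured compounds named here, in a functional assay on MT4 cells (Homo sapiens) for cytotoxicity (a higher number here means a weaker inhibitor, a lower number a stronger inhibitor), three compounds built on the same core have numbers so far. Compound 1 `COc1ccccc1S(=O)(=O)c1cccc(N)c1C#N` gives 146000 nM. Compound 2 `Cc1ccccc1S(=O)(=O)c1cccc(N)c1C#N` is recorded only as a limit of the assay, > 200000 nM. Compound 3 `N#Cc1c(N)cccc1S(=O)(=O)c1ccccc1Br` gives 40000 nM, the lowest number of the three. Bromo in place of methoxy gives a 3.7-fold lower number from compound 1 to compound 3 (0.56 log units; beyond the scatter), and bromo in place of methyl gives an at least 5.0-fold lower number from compound 2 to compound 3 (0.69 log units; beyond the scatter).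

Compound 4 `N#Cc1ccccc1S(=O)(=O)c1cccc(N)c1C#N` follows from compound 3 by one change, cyano in place of bromo on an aromatic carbon, ortho to a large group: cyano in place of bromo on an aromatic carbon. Going by the values given here, no measured step involves this cyano group, so those two bromo steps are the nearest guide. Both replacements lowered the number, and compound 3 would lose the bromo that set it apart. A modest rise is therefore expected in this assay, of about the size seen in a 3.7-fold lower number from compound 1 to compound 3 (0.56 log units; beyond the scatter). The expected change is a 2.8-fold higher number from compound 3 to compound 4 (0.44 log units; beyond the scatter). For compound 4 the estimated value is 110000 nM, with an expected range of 40000 nM to 200000 nM.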

Compound 4, half-maximal inhibitory concentration: > 200000 nM
Compound 4 ended at the assay's limit (the forecaster's own chance of this, stated with the estimate: 30%); at least 1.8-fold (0.25 log units) between middle value and limit.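

Cyano in place of bromo on this aromatic carbon, ortho to a large group, gives an at least 5.0-fold higher number from compound 3 to compound 4 (0.69 log units; beyond the scatter) in this assay, so the fall in the number seen with bromo is not kept with cyano. Cyano in place of methoxy gives an at least 1.3-fold higher number from compound 1 to compound 4 (0.13 log units; that floor lies within the scatter), which does not separate the two groups. Among the four groups now shown at this position, only bromo has steps beyond the scatter to all the others, while compound 4 is recorded only as a limit, the same limit as compound 2: the limit of > 200000 nM in this assay, at which 2 of the 4 values shown sit.

The step between compound 2 and compound 4 cannot be read, as both values are limits, so methyl and cyano cannot be ordered here. On these data alone, it remains open whether chloro, fluoro, an amine or a carboxylic acid at this position would give a number as low as bromo does.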